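From Methyl Back to a Halogen-Type Substituent

This account rests on a few compounds, and the source may have more. Where it says the series, first, only, none or still open, it means among the compounds named here.

Compound 1 `Clc1ccc(-c2nc3ccccn3c2NC2CCCCC2)cc1` in an assay on membranes from brain for displacement of a labelled ligand from adenosine receptor A1 (Rattus norvegicus); on this read-out lower numbers stand for stronger inhibition and higher numbers for weaker inhibition: > 100000 nM.
Compound 2 `Cc1ccc(-c2nc3ccccn3c2NC2CCCCC2)cc1` in this assay: 2060 nM.

The value of compound 1, > 100000 nM, is a limit of the assay, not a number. For the measured compounds named here, compound 2 gives 2060 nM, the only number seen here. Compound 3 `Brc1ccc(-c2nc3ccccn3c2NC2CCCCC2)cc1` differs from compound 2 by bromo in place of methyl on an aromatic carbon. Going by the values given here, the single measured step bearing on this is an at least 48-fold lower number from compound 1 to compound 2 (1.68 log units; beyond the scatter), chloro to methyl; the change now runs the other way, methyl to bromo, so a large step to a higher number is expected, a 29-fold higher number from compound 2 to compound 3 (1.46 log units; beyond the scatter), possibly reaching (the limit of > 100000 nM in this assay, at which 1 of the 2 values shown sits). Compound 3 is therefore estimated at 60000 nM, between 8000 nM and 300000 nM.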

Compound 3, inhibition constant: 3900 nM
Compound 3: the middle estimate sits 15-fold (1.19 log units) above what was measured, and the stated range ends above it.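

In this assay, bromo in place of methyl gives a 1.9-fold higher number from compound 2 to compound 3 (0.28 log units; within the scatter), so at this position the two groups cannot be told apart. Bromo in place of chloro gives an at least 25-fold lower number from compound 1 to compound 3 (1.40 log units; beyond the scatter), so a halogen on this aromatic carbon does not by itself go with the weak binding of compound 1, and compound 3 goes against any such pattern. Compound 1 alone stands at a limit, not a number: the limit of > 100000 nM in this assay, at which 1 of the 3 values shown sits.

Going by these compounds, what fluoro, methoxy or an amine would do on this carbon stays open. So does whether chloro is as exceptional with another group in place of the cyclohexyl ring.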